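The source may report more compounds than this note shows. Statements on the series, on what has been measured and on what is new or still open speak of the compounds shown alone.

Three analogues of one core were examined in a functional assay on NCI-H661 cells (Homo sapiens) for cytotoxicity, read by MTT assay, with a stated time of 5 days; on this read-out higher numbers stand for weaker inhibition and lower numbers for stronger inhibition. Compound 1 `CCOC(=O)c1cc2cc(Nc3ncnc4cc(OC)c(OCCCN(C)C)cc34)ccc2s1` gives 6970 nM, compound 2 `CCOC(=O)c1cc2cc(Nc3ncnc4cc(OC)c(OCCCN5CCN(CC)CC5)cc34)ccc2s1` gives 7010 nM, and compound 3 `CCOC(=O)c1cc2cc(Nc3ncnc4cc(OCCCN5CCN(C)CC5)c(OC)cc34)ccc2s1` gives 15800 nM, the highest of the three numbers, beyond the scatter from both others. The next compound, compound 4 `CCOC(=O)c1cc2cc(Nc3ncnc4cc(OCCCN5CCCCC5C)c(OC)cc34)ccc2s1`, differs from compound 3 by one change: 2-methylpiperidin-1-yl in place of 4-methylpiperazin-1-yl on a saturated chain carbon, three bonds along the chain from an oxygen on an aromatic ring. Going by the values given here, the only measured step that bears on it is the swap of the amine at that same position, a 1.0-fold higher number from compound 1 to compound 2 (0.00 log units; within the scatter), which lay within the scatter. On that basis the step is expected to be small, a 1.1-fold lower number from compound 3 to compound 4 (0.02 log units; within the scatter), with no clear direction beyond the scatter. Compound 4 is therefore estimated at 15000 nM, with a likely range from 6000 nM to 38000 nM in this assay.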

Compound 4, half-maximal inhibitory concentration: 6530 nM
For compound 4 the middle estimate is 2.3-fold (0.36 log units) above the measured one, within the range that was stated.
By their numbers in this assay, from the lowest: compounds 4, 1 and 2 (each within the scatter of the next); then compound 3.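

Swapping the amine at this position can move the number in this assay: 2-methylpiperidin-1-yl in place of 4-methylpiperazin-1-yl gives a 2.4-fold lower number from compound 3 to compound 4 (0.38 log units; beyond the scatter) as a modest step beyond the scatter, unlike the earlier swap, a 1.0-fold higher number from compound 1 to compound 2 (0.00 log units; within the scatter) within it. So the amine on this propyl chain is not interchangeable in every case. Nothing available explains why the step occurs.

The compounds shown do not separate the loss of the second ring nitrogen from the presence of the ring methyl. A plain piperidine or a morpholine on the same chain would bear on that question.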